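This account rests on a few compounds, and the source may have more. Where it says the series, first, only, none or still open, it means among the compounds named here.

Measured so far:
- Compound 1 `CC1=CC[C@H](C(C)(C)NC(=S)N/N=C/c2ccccc2O)CC1`: in an ADME assay on Vero cells (Chlorocebus sabaeus) for inhibition, read by sulforhodamine B assay, with a stated time of 48 h (a higher number here means a weaker inhibitor of growth, a lower number a stronger inhibitor of growth), compound 1 gives 3100 nM.
- Compound 2 `CC1=CC[C@H](C(C)(C)NC(=S)N/N=C/c2ccccc2[N+](=O)[O-])CC1`: compound 2 gives 21600 nM.
- Compound 3 `CC1=CC[C@H](C(C)(C)NC(=S)N/N=C/c2cccc([N+](=O)[O-])c2)CC1`: compound 3 sits at a limit of the assay, > 100000 nM.

Compound 1 holds the lowest of the two numbers given; the nearest is compound 2, reached by the step of a 7.0-fold higher number from compound 1 to compound 2 (0.84 log units; beyond the scatter). Compound 3 shows only the limit of > 100000 nM in this assay, at which 1 of the 3 values shown sits, and carries no number of its own.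

Compound 4 `CC1=CC[C@H](C(C)(C)NC(=S)N/N=C/c2ccc[nH]2)CC1` is the next compound for this assay. It differs from compound 1 by 1H-pyrrol-2-yl in place of 2-hydroxyphenyl on a carbon with a double bond to nitrogen. Among the compounds with values here, no measured step replaces the 2-hydroxyphenyl ring as a whole, so the only guide is the single change at that ring, nitro in place of hydroxy, which gave a 7.0-fold higher number from compound 1 to compound 2 (0.84 log units; beyond the scatter). That step removed the hydroxy and the number rose modestly; the change to compound 4 also removes it, and a rise of similar modest size is therefore taken as the working expectation rather than no change. Compound 4 is estimated at 8000 nM, with a range from 2500 nM to 30000 nM. This estimate corresponds to an expected step of a 2.6-fold higher number from compound 1 to compound 4 (0.41 log units; beyond the scatter).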

Compound 4, concentration for 50% growth inhibition: 20500 nM
Estimate against measurement, compound 4: 2.6-fold (0.41 log units) below; the measured number falls inside the stated range.
By their numbers in this assay, from the lowest: compound 1; then compounds 4 and 2 (each within the scatter of the next). At a limit, above all of these: compound 3.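

In this assay, exchanging the whole ring on the carbon with a double bond to nitrogen gives a 6.6-fold higher number from compound 1 to compound 4 (0.82 log units; beyond the scatter), so a five-membered aromatic ring with a hetero atom does not hold the number of compound 1. The entering 1H-pyrrol-2-yl has the same count of hydrogen-bond donors as the leaving 2-hydroxyphenyl, so that count alone does not set the number, and compound 4 and compound 2 lie within the scatter of each other. Nothing measured here gives a cause for this step.

From the compounds shown here alone, it stays open whether the number of compound 1 depends on the hydroxy itself or on the six-membered ring that carries it. An unsubstituted phenyl and a methoxy-bearing phenyl would separate these two readings.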